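This account rests on a few compounds, and the source may have more. Where it says the series, first, only, none or still open, it means among the compounds named here.

Compound 3 `CNC(=O)c1cc(Oc2ccc(C(=O)/C=C/c3ccc(Cl)cc3Cl)cc2)ccn1` carries a 2,4-dichlorophenyl group on the double-bonded chain carbon bound to a double-bonded chain carbon, and in a functional assay on PC-3 cells (Homo sapiens) for cytotoxicity, read by MTT assay, with a stated time of 72 h (a higher number here means a weaker inhibitor, a lower number a stronger inhibitor), compound 3 gives 9220 nM. That is the higher of the two numbers available: compound 2 `CNC(=O)c1cc(Oc2ccc(C(=O)/C=C/c3cc(OC)c(OC)c(OC)c3)cc2)ccn1` gives 3150 nM in this assay, and the gap between the two lies beyond the scatter. Compound 1 `CNC(=O)c1cc(Oc2ccc(/C=C/C(=O)c3ccc([N+](=O)[O-])cc3)cc2)ccn1` has no number in this assay, where compound 1 is recorded as "not determined" (no result reported).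

Compound 4 `CNC(=O)c1cc(Oc2ccc(C(=O)/C=C/c3ccc([N+](=O)[O-])cc3)cc2)ccn1` has not yet been measured. Relative to compound 3, the change is 4-nitrophenyl in place of 2,4-dichlorophenyl on a double-bonded chain carbon bound to a double-bonded chain carbon. Among the compounds with values here, no pair of measured compounds shows this exact change, so the size of the step cannot be read directly from the data. The two numbers that exist suggest that groups of this kind on the chain end can move the result by a modest amount, and the expectation is that compound 4 will fall close to compound 3, with at most a small shift toward a lower number, a step of a 1.4-fold lower number from compound 3 to compound 4 (0.15 log units; within the scatter) that may well remain within the scatter. In this assay compound 4 is therefore estimated at 6500 nM, with a range from 2200 nM to 19000 nM.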

Compound 4, half-maximal inhibitory concentration: 11100 nM
Beside the measured number, compound 4's estimate is 1.7-fold (0.23 log units) below it; measured number inside the range.
By their numbers in this assay, from the lowest: compound 2; then compounds 3 and 4 (each within the scatter of the next).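

In this assay, within the data shown here, putting 4-nitrophenyl in place of 2,4-dichlorophenyl on a double-bonded chain carbon bound to a double-bonded chain carbon gives a 1.2-fold higher number from compound 3 to compound 4 (0.08 log units; within the scatter), the first direct reading of a single change at this position. It shows that these two groups cannot be told apart in this measurement, even though one brings two chlorine atoms and no hydrogen-bond acceptors, while the other brings a nitro group with its hydrogen-bond acceptors and one more heavy atom. No measurement at hand accounts for this result.

One matched pair cannot show whether the position is insensitive in general or whether these two groups merely happen to read alike. On these data alone, how a phenyl ring bearing an amine or a carboxylic acid would read at this place remains open, as does the reading for a ring carrying a single chlorine atom, which would help to separate the contribution of each chlorine in compound 3.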